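This account rests on a few compounds, and the source may have more. Where it says the series, first, only, none or still open, it means among the compounds named here.

Measured in a functional assay on L1210 cells (Mus musculus) for inhibition; on this read-out higher numbers stand for weaker inhibition and lower numbers for stronger inhibition:
- compound 1 `O=C1/C(=C/c2ccc(F)cc2)Cc2ccccc21`: 89000 nM
- compound 2 `O=C1/C(=C/c2ccc(Cl)cc2)Cc2ccccc21`: 54100 nM
- compound 3 `O=C1/C(=C/c2ccc(Br)cc2)Cc2ccccc21`: 64800 nM

Compound 3 cannot be told apart from the other two, with a 1.2-fold higher number from compound 2 to compound 3 (0.08 log units; within the scatter) and a 1.4-fold lower number from compound 1 to compound 3 (0.14 log units; within the scatter). Compound 4 `Cc1ccc(/C=C2\Cc3ccccc3C2=O)cc1` has methyl in place of bromo on an aromatic carbon. Among the measured compounds shown here, the steps that bear on this are the swaps among fluoro, chloro and bromo at that same place. Besides the two above, there is a 1.6-fold lower number from compound 1 to compound 2 (0.22 log units; within the scatter). All stayed small, but none involves methyl, so this is an extrapolation, and no change beyond the scatter is expected. The expected step is a 1.1-fold lower number from compound 3 to compound 4 (0.03 log units; within the scatter). Compound 4 is estimated at 60000 nM, with an expected range from 30000 nM to 120000 nM.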

Compound 4, half-maximal inhibitory concentration: 59100 nM
Estimate against measurement, compound 4: 1.0-fold (0.01 log units) above; measured number inside the range.
By their numbers in this assay, from the lowest: compounds 2, 4, 3 and 1 (each within the scatter of the next).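

Methyl in place of bromo stays within the scatter (a 1.1-fold lower number from compound 3 to compound 4 (0.04 log units; within the scatter)), as does methyl in place of chloro (a 1.1-fold higher number from compound 2 to compound 4 (0.04 log units; within the scatter)) and methyl in place of fluoro (a 1.5-fold lower number from compound 1 to compound 4 (0.18 log units; within the scatter)). So at this place, on the aromatic carbon para to a large group, a carbon group gives a number that cannot be told apart from those of the three halogens. No other measurement here bears on the reason for this.

Still open, as far as these compounds go, is whether an amine, a carboxylic acid or a longer chain at this place would move the number beyond the scatter.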